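The compounds below may be only part of what the source reports. "The series", "measured", "known", "first", "only" and "open" are said of these compounds alone.

Going by the values given here, in a functional assay on MCF7 cells (Homo sapiens) for antiproliferative activity, read by MTT assay, with a stated time of 72 h (a higher number here means a weaker inhibitor, a lower number a stronger inhibitor), compound 2 (`CCCSc1nc(N/N=C/c2c[nH]c3ccccc23)c2nnn(Cc3ccccc3)c2n1`) gives 9010 nM, the lower of the two numbers so far. Compound 1 (`CCCSc1nc(N/N=C/c2cccnc2)c2nnn(Cc3ccccc3)c2n1`) gives 58700 nM. Next is compound 3 (`CCCSc1nc(N/N=C/c2ccc(Br)cc2)c2nnn(Cc3ccccc3)c2n1`), with the change 4-bromophenyl in place of 1H-indol-3-yl on a carbon with a double bond to nitrogen. Among the compounds with values here, only one measured step bears on this, on the same carbon: a 6.5-fold lower number from compound 1 to compound 2 (0.81 log units; beyond the scatter), a modest step with 1H-indol-3-yl in place of pyridin-3-yl. Within the data shown here, no measured compound carries 4-bromophenyl, so this single step is a loose guide. Giving up the 1H-indol-3-yl of compound 2 at 9010 nM is expected to raise the number in this assay by a modest amount, smaller than that step. The expected step is a 2.0-fold higher number from compound 2 to compound 3 (0.30 log units; within the scatter). Compound 3 is estimated at 18000 nM, with an expected range from 6000 nM to 50000 nM.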

Compound 3, half-maximal inhibitory concentration: > 64000 nM
Compound 3 gave a limit, no number; the forecaster's own chance of this, stated with the estimate: 10%; middle value at least 3.5-fold (0.55 log units) away from the limit.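

In this assay compound 3 carries a limit of the assay, not a number: the limit of > 64000 nM in this assay, at which 1 of the 3 values shown sits.

Even so, the change to 4-bromophenyl brings an at least 7.1-fold higher number from compound 2 to compound 3 (0.85 log units; beyond the scatter) on this carbon with a double bond to nitrogen, so 1H-indol-3-yl now stands clear of a second group and not only of pyridin-3-yl. With 4-bromophenyl in place of pyridin-3-yl the step is an at least 1.0-fold higher number from compound 1 to compound 3 (0.03 log units; that floor lies within the scatter) and so leaves these two groups unordered.

From the compounds shown here alone, the change removes the hydrogen-bond donor and the five-membered aromatic ring together, so it remains open which of the two, if either, goes with the loss. Also open, going by these compounds, is whether an amine or a carboxylic acid on the phenyl ring in this place would stay with compound 3 or come closer to compound 2.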